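The source may report more compounds than this note shows. Statements on the series, on what has been measured and on what is new or still open speak of the compounds shown alone.

Compound 1 `C=CC(=O)NCC#Cc1ccc2ncn(-c3ccnc(N)n3)c2c1` holds the lowest of the two plain numbers recorded in an assay on Sf9 cells for inhibition of mitogen-activated protein kinase kinase kinase 14 variant S549D (Homo sapiens), with a stated time of 30 min, in the presence of a further agent that is not named here; on this read-out higher numbers stand for weaker inhibition and lower numbers for stronger inhibition: compound 1 gives 6310 nM. Compound 2 `CC(=O)NCCCc1ccc2ncn(-c3ccnc(N)n3)c2c1` reaches only a limit of this assay, giving > 100000 nM. Compound 3 `CC(=O)NCCCCc1ccc2ncn(-c3ccnc(N)n3)c2c1` gives 398000 nM in this assay. Both measured steps from compound 1 exchange the 3-((vinylcarbonyl)amino)prop-1-yn-1-yl group for a saturated acetamide chain: the step of an at least 15-fold higher number from compound 1 to compound 2 (1.19 log units; beyond the scatter) and the step of a 63-fold higher number from compound 1 to compound 3 (1.80 log units; beyond the scatter) are both large, and the first runs into (the limit of > 100000 nM in this assay, at which 1 of the 3 values shown sits). The step that the limit leaves unreadable from compound 2 to compound 3 cannot be sized.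

Compound 4 `C#Cc1cncc(C#Cc2ccc3ncn(-c4ccnc(N)n4)c3c2)c1` keeps the triple bond but changes what hangs on it: a group of 8 heavy atoms (7 carbon, 1 nitrogen; one six-membered aromatic ring with 1 hetero atom) in place of a group of 6 heavy atoms (4 carbon, 1 nitrogen, 1 oxygen; no ring), on a triple-bonded carbon. Going by the values given here, no measured step removes the ((vinylcarbonyl)amino)methyl group while keeping the triple bond, so the two measured steps bear on this change only loosely, though both show that losing that group raises the number a great deal. The number for compound 4 is therefore expected to rise by a 4.0-fold higher number from compound 1 to compound 4 (0.60 log units; beyond the scatter), less than in those steps. Compound 4 is estimated at 25000 nM, with a range from 4000 nM to 150000 nM.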

Compound 4, half-maximal inhibitory concentration: 63100 nM
The estimate for compound 4 lay 2.5-fold (0.40 log units) below the measured number, within the range that was stated.
By their numbers in this assay, from the lowest: compound 1; then compound 4; then compound 3.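

In this assay, going by these compounds alone, the earlier steps removed the triple bond and the ((vinylcarbonyl)amino)methyl group together, whereas this change keeps the triple bond and replaces only what hangs on it, giving a 10-fold higher number from compound 1 to compound 4 (1.00 log units; beyond the scatter). The triple bond alone therefore does not preserve the number of compound 1: on this triple-bonded carbon, the new group with its six-membered aromatic ring and 0 hydrogen-bond donors is a clear step weaker than the ((vinylcarbonyl)amino)methyl group. No measurement shown explains which feature of the departing group accounts for this difference.

Going by these compounds, it remains open how a plain aminomethyl or (acetylamino)methyl group would compare on the same carbon. Such a pair would help separate the contribution of the vinylcarbonyl double bond from that of the amide.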